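Chloro to hydroxy on the alkynyl chain

The compounds below may be only part of what the source reports. "The series", "measured", "known", "first", "only" and "open" are said of these compounds alone.

Measured values in a functional assay on L1210 cells (Mus musculus) for inhibition (a higher number here means a weaker inhibitor, a lower number a stronger inhibitor), are as follows:
- compound 1 `Cc1cn(C/C=C\CCl)c(=O)[nH]c1=O` at 46000 nM
- compound 2 `Cc1cn(C/C=C\CO)c(=O)[nH]c1=O` at > 1000000 nM
- compound 3 `Cc1cn(CC#CCCl)c(=O)[nH]c1=O` at 140000 nM

Compound 2 stands at a limit of the assay, not at a number. Among the two exact numbers, compound 3 (140000 nM) is the higher, and the gap is modest (a 3.0-fold higher number from compound 1 to compound 3 (0.48 log units; beyond the scatter)).

The next compound, compound 4 `Cc1cn(CC#CCO)c(=O)[nH]c1=O`, puts hydroxy in place of chloro on a saturated chain carbon bound to a triple-bonded carbon. Going by the values given here, the closest precedent is the same exchange on the double-bonded chain, which was large (an at least 21-fold higher number from compound 1 to compound 2 (1.33 log units; beyond the scatter)). The exchange of the chain itself was much smaller (a 3.0-fold higher number from compound 1 to compound 3 (0.48 log units; beyond the scatter)), so the precedent is taken to carry over to the triple-bonded chain. The mixed step an at least 7.1-fold lower number from compound 2 to compound 3 (0.85 log units; beyond the scatter) changes both places at once and adds little.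

A large rise in the number is therefore expected in this assay (a 21-fold higher number from compound 3 to compound 4 (1.33 log units; beyond the scatter)). Compound 4 may well be reported only as a limit, like compound 2 (the limit of > 1000000 nM in this assay, at which 1 of the 3 values shown sits). Compound 4 is estimated at 3000000 nM (expected range 800000 nM to 12000000 nM).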

Compound 4, half-maximal inhibitory concentration: > 500000 nM
Compound 4: a limit, no number; the forecaster's own chance of this, stated with the estimate: 80%; the middle value does not contradict the limit.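

In this assay, the exchange of chloro for hydroxy now also weakens inhibition on the triple-bonded chain (an at least 3.5-fold higher number from compound 3 to compound 4 (0.55 log units; beyond the scatter)), so the direction seen on the double-bonded chain holds at a saturated chain carbon bound to a triple-bonded carbon. Compound 4 is reported only as a limit, and it also lies well on the weak side of compound 1 (an at least 10-fold higher number from compound 1 to compound 4 (1.03 log units; beyond the scatter)), while the step between compound 2 and compound 4 cannot be read, as both are limits. Whether the chain type alters the size of the exchange remains unsettled: the same change on two cores in this assay, an at least 21-fold higher number (1.33 log units; beyond the scatter) from compound 1 to compound 2 and an at least 3.5-fold higher number (0.55 log units; beyond the scatter) from compound 3 to compound 4; the limit leaves it open whether they differ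

Only chloro and hydroxy have been shown on this chain carbon, so it remains open whether bromo, methoxy or an amine at the same place would stay near compound 1 and compound 3 or fall away as hydroxy does. As far as these compounds go, the effect of a longer chain carrying the chloro also remains open, as does the actual number for compound 4 beyond its limit.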